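From an Acid to a Chlorophenyl Amide

The compounds below may be only part of what the source reports. "The series", "measured", "known", "first", "only" and "open" are said of these compounds alone.

In a functional assay on KB cells (Homo sapiens) for inhibition, read by MTT assay, with a stated time of 24 h, tested at 1 ug/mL (a higher number here means more inhibition of growth at the concentration tested, a lower number less inhibition of growth), compound 1 (`CC(=O)SCCC(CCCCC(=O)O)SC(C)=O`) gives 12.4%. Compound 3 (`COc1ccc(NC(=O)CCCCC(S)CCS)cc1`) gives 2.49%, within the usual scatter of compound 1. Compound 2 (`O=C(CCCCC1CCSS1)Nc1ccc(OC(F)(F)F)cc1`) gives 1.54%, lower than compound 1 by more than that scatter. Compound 4 (`CC(=O)SCCC(CCCCC(=O)Nc1ccc(Cl)cc1)SC(C)=O`) has (4-chlorophenyl)amino in place of hydroxy on a carbonyl carbon of compound 1: (4-chlorophenyl)amino in place of hydroxy on a carbonyl carbon. Compound 2 and compound 3 are also amides carrying an aromatic ring, but they differ from compound 4 elsewhere, so they are only a loose guide. Both stay low, with compound 3 at 2.49%. A modest downward step is therefore expected, estimated as a number 7.4 percentage points lower from compound 1 to compound 4 (within the scatter), possibly within the scatter. For compound 4 the estimated value is 5%, with an expected range of 0% to 16%.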

Compound 4, percent growth inhibition at one concentration: 14.8%
Compound 4: the middle estimate sits 9.8 percentage points below what was measured; the range from low to high includes it.
By their numbers in this assay, from the lowest: compounds 2, 3, 1 and 4 (each within the scatter of the next, the first and the last beyond it).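

Swapping hydroxy for (4-chlorophenyl)amino on a carbonyl carbon gives a number 2.4 percentage points higher from compound 1 to compound 4 (within the scatter) in this assay and so shows no real shift. This position therefore accepts a much larger group carrying an aromatic ring, and the free carboxylic acid of compound 1 is not needed to keep this reading. No available data bear on why the reading holds.

As far as these compounds go, whether phenylamino without the chlorine, or a methyl ester, would read the same on this carbonyl carbon remains open. A single test concentration also leaves open how compound 1 and compound 4 behave at higher doses.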